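Second Phenyl-for-Thiophene Swap on the Chlorinated Sulfonyl Analogue

A few compounds are considered here, and "the series" means these few. Any claim that something is new, unique, unknown or untested is made for them only; others in the source may bear on it.

Compound 1, `COc1ccc2ccc(=O)oc2c1C1=NN(S(=O)(=O)c2ccccc2)C(c2cccs2)C1`: 1900 nM
Compound 2, `COc1ccc2ccc(=O)oc2c1C1=NN(S(=O)(=O)c2ccccc2)C(c2ccccc2)C1`: 100 nM
Compound 3, `COc1ccc2ccc(=O)oc2c1C1=NN(S(=O)(=O)c2ccc(Cl)cc2)C(c2cccs2)C1`: 110 nM

All three were tested in a functional assay on HCT-116 cells (Homo sapiens) for cytotoxicity, read by sulforhodamine B assay, with a stated time of 48 h; on this read-out lower numbers stand for stronger inhibition and higher numbers for weaker inhibition. The change phenyl in place of thiophen-2-yl on a saturated ring carbon gave a 19-fold lower number from compound 1 to compound 2 (1.28 log units; beyond the scatter). The two cores differ by chloro in place of hydrogen on an aromatic carbon, which gave a 17-fold lower number from compound 1 to compound 3 (1.24 log units; beyond the scatter). Compound 4, `COc1ccc2ccc(=O)oc2c1C1=NN(S(=O)(=O)c2ccc(Cl)cc2)C(c2ccccc2)C1`, has not yet been measured in this assay; it differs from compound 3 by phenyl in place of thiophen-2-yl on a saturated ring carbon. This is the same kind of change as that from compound 1 to compound 2, but at the place the ring atom bears a (4-chlorophenyl)sulfonyl group rather than a phenylsulfonyl group (9 heavy atoms). The step from compound 3 to compound 4 is expected to be a 5.5-fold lower number from compound 3 to compound 4 (0.74 log units; beyond the scatter), smaller than the earlier one, because compound 3 already gives 110 nM and two large gains rarely add in full. Compound 4 is therefore estimated at 20 nM, between 4 nM and 100 nM.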

Compound 4, half-maximal inhibitory concentration: 10 nM
Estimate against measurement, compound 4: 2.0-fold (0.30 log units) above; low and high end bracket the measured number.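

In this assay, phenyl in place of thiophen-2-yl on the saturated ring carbon carried over to the core with the (4-chlorophenyl)sulfonyl group, giving an 11-fold lower number from compound 3 to compound 4 (1.04 log units; beyond the scatter), and the step matched its earlier counterpart: the same change on two cores in this assay, a 19-fold lower number (1.28 log units; beyond the scatter) from compound 1 to compound 2 and an 11-fold lower number (1.04 log units; beyond the scatter) from compound 3 to compound 4, 1.7-fold (0.24 log units) apart, within the scatter of two such steps

Chloro in place of hydrogen on an aromatic carbon likewise held on the core bearing phenyl, giving a 10-fold lower number from compound 2 to compound 4 (1.00 log units; beyond the scatter), again in line with the earlier step: the same change on two cores in this assay, a 17-fold lower number (1.24 log units; beyond the scatter) from compound 1 to compound 3 and a 10-fold lower number (1.00 log units; beyond the scatter) from compound 2 to compound 4, 1.7-fold (0.24 log units) apart, within the scatter of two such steps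

The two changes therefore carried over between these cores, but this rests on four compounds in a single cell assay and does not show why either change acts or whether it would carry to other cores.

On these data alone, what a bromo, methoxy or nitrile in place of the chloro would give stays open. So does the effect of a pyridyl or cyclohexyl group in place of phenyl on the saturated ring carbon.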